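Swapping a Ring Among Closely Matched Values

The compounds below may be only part of what the source reports. "The series", "measured", "known", "first", "only" and "open" are said of these compounds alone.

In a functional assay on HepG2 cells (Homo sapiens) for cytotoxicity, read by MTT assay, with a stated time of 72 h (on this read-out lower numbers stand for stronger inhibition and higher numbers for weaker inhibition), compound 1 `O=C(N/N=C/c1cccc(Cl)c1Cl)Nc1cc2c(Nc3ccc(F)c(Cl)c3)ncnc2cc1O[C@H]1CCOC1` gives 16900 nM, compound 2 `COc1ccc(/C=N/NC(=O)Nc2cc3c(Nc4ccc(F)c(Cl)c4)ncnc3cc2O[C@H]2CCOC2)c(OC)c1OC` gives 29300 nM and compound 3 `COc1cc2ncnc(Nc3ccc(F)c(Cl)c3)c2cc1NC(=O)N/N=C/c1cccc(Cl)c1Cl` gives 26100 nM. Compound 3 thus stands within the usual scatter of the other two. Compound 4 `COc1cc2ncnc(Nc3ccc(F)c(Cl)c3)c2cc1NC(=O)N/N=C/c1ccc(O)cc1` has 4-hydroxyphenyl in place of 2,3-dichlorophenyl on a carbon with a double bond to nitrogen. Among the measured compounds shown here, the closest precedent also removes 2,3-dichlorophenyl, and its step of a 1.7-fold higher number from compound 1 to compound 2 (0.24 log units; within the scatter) stayed within the scatter. The change elsewhere in the structure, a 1.5-fold higher number from compound 1 to compound 3 (0.19 log units; within the scatter), did too. No step beyond the scatter is therefore expected in this assay, and the estimated step is a 1.0-fold lower number from compound 3 to compound 4 (0.02 log units; within the scatter). For compound 4 the expected value is 25000 nM, with an estimated range of 10000 nM to 60000 nM.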

Compound 4, half-maximal inhibitory concentration: 26300 nM
Compound 4: the middle estimate sits 1.1-fold (0.02 log units) below what was measured, and the stated range covers the measured number.
By their numbers in this assay, from the lowest: compounds 1, 3, 4 and 2 (each within the scatter of the next).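

On the carbon with a double bond to nitrogen, 4-hydroxyphenyl replaces 2,3-dichlorophenyl with a 1.0-fold higher number from compound 3 to compound 4 (0.00 log units; within the scatter) in this assay, so a ring carrying a hydrogen-bond donor and acceptor reads the same as a ring with neither. With a 1.7-fold higher number from compound 1 to compound 2 (0.24 log units; within the scatter) as the earlier ring swap, this is a second change at this place that stays within the scatter, now with methyl rather than oxolan-3-yl on the oxygen. No available evidence accounts for this flat result.

On these data alone, whether an amine or a carboxylic acid on this ring, or a longer chain in its place, would move the number beyond the scatter remains open.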